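Vinyl in place of dibromoethenyl on a dihydropyran side chain

The compounds below may be only part of what the source reports. "The series", "measured", "known", "first", "only" and "open" are said of these compounds alone.

Measured so far:
compound 1, `C[Si](C)(C)C1=C(Cl)C[C@H](C2CCCCC2)O[C@@H]1C1CCCCC1`, 22000 nM
compound 2, `C[C@@H]1O[C@H](CCC=C(Br)Br)C([Si](C)(C)C)=C(Cl)[C@H]1C`, 16000 nM

In a functional assay on A2780 cells (Homo sapiens) for antiproliferative activity (on this read-out higher numbers stand for weaker inhibition of growth and lower numbers for stronger inhibition of growth), compound 1 gives 22000 nM. In this assay compound 2 gives 16000 nM. The two numbers lie within the scatter of each other, so neither compound can be set above the other; compound 2 simply stands alongside compound 1 at the weak end of what has been measured. Among the compounds with values here, no step between measured compounds is available to guide an expectation.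

Compound 3, `C=CCC[C@H]1O[C@@H](C)[C@H](C)C(Cl)=C1[Si](C)(C)C`, differs from compound 2 in one place: vinyl in place of 2,2-dibromoethenyl on a saturated chain carbon, two bonds along the chain from a saturated ring carbon. The two bromine atoms leave and a bare vinyl remains. Within the data shown here, with only two weak numbers and no comparable step to draw on, the expected step in this assay from compound 2 to compound 3 is none beyond the scatter, with a slight lean toward a weaker number. Compound 3 is therefore estimated at 25000 nM, within the range from 8000 nM to 80000 nM, a step of a 1.6-fold higher number from compound 2 to compound 3 (0.19 log units; within the scatter).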

Compound 3, concentration for 50% growth inhibition: 17000 nM
Compound 3: middle estimate off by 1.5-fold (0.17 log units), on the high side; the range from low to high includes it.
By their numbers in this assay, from the lowest: compounds 2, 3 and 1 (each within the scatter of the next).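

In this assay, vinyl in place of 2,2-dibromoethenyl on a saturated chain carbon, two bonds along the chain from a saturated ring carbon, gives a 1.1-fold higher number from compound 2 to compound 3 (0.03 log units; within the scatter). Within the data shown here, this single-place comparison, which the earlier compounds could not provide, shows that at this position the two bromine atoms can be lost without a change that stands out from the scatter, so they are not needed to hold the number where it is. Nothing available explains why the number holds.

The compounds shown leave open whether this chain end responds to any change at all, since both groups compared are unsaturated carbon ends. A primary amine, a carboxylic acid or a longer chain at this place might still move the number beyond the scatter.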